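Changing the amide substituent on a shared sulfonylpiperidine core

The compounds below may be only part of what the source reports. "The series", "measured", "known", "first", "only" and "open" are said of these compounds alone.

Two compounds have been measured in a functional assay on MIA PaCa-2 cells (Homo sapiens) for inhibition, read by MTT assay, with a stated time of 7 days; a higher number here means a weaker inhibitor, a lower number a stronger inhibitor:

compound 1 `CCN(CC)S(=O)(=O)c1ccc(S(=O)(=O)N2CCC[C@@H](C(=O)N[C@H]3CC[C@H](OC)CC3)C2)cc1`: 1350 nM
compound 2 `CCN(CC)S(=O)(=O)c1ccc(S(=O)(=O)N2CCC[C@@H](C(=O)N[C@H]3CCOC3)C2)cc1`: 1670 nM

Compound 2 gives the higher of the two numbers, but its nearest neighbour is compound 1, and the step of a 1.2-fold higher number from compound 1 to compound 2 (0.09 log units; within the scatter) falls within the scatter, so the two cannot be told apart in this assay. That step swapped one group on the amide-type nitrogen for another and left the number essentially where it was.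

Compound 3 `CCN(CC)S(=O)(=O)c1ccc(S(=O)(=O)N2CCC[C@@H](C(=O)N3CCC(COC)CC3)C2)cc1` is the next compound. Its difference from compound 2 is 4-(methoxymethyl)piperidin-1-yl in place of (oxolan-3-yl)amino on a carbonyl carbon. For the measured compounds named here, no measured step covers this exact change. Going by the values given here, the only step available, from compound 1 to compound 2, also altered what sits on the carbonyl carbon, and it was small (a 1.2-fold higher number from compound 1 to compound 2 (0.09 log units; within the scatter)). On that basis a small step in this assay, with no clear direction, is the expectation. For compound 3 the estimated value is 1800 nM, within a range of 700 nM to 4500 nM, which corresponds to an expected step of a 1.1-fold higher number from compound 2 to compound 3 (0.03 log units; within the scatter).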

Compound 3, half-maximal inhibitory concentration: 250 nM
Compound 3: middle estimate off by 7.2-fold (0.86 log units), on the high side; the measured number lies below the stated range.
By their numbers in this assay, from the lowest: compound 3; then compounds 1 and 2 (each within the scatter of the next).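

In this assay, the group on this carbonyl carbon now proves able to shift the number beyond the scatter: 4-(methoxymethyl)piperidin-1-yl in place of (oxolan-3-yl)amino gives a 6.7-fold lower number from compound 2 to compound 3 (0.82 log units; beyond the scatter), and in place of (4-methoxycyclohexyl)amino it gives a 5.4-fold lower number from compound 1 to compound 3 (0.73 log units; beyond the scatter). The entering group differs from (oxolan-3-yl)amino in several ways at once, with its nitrogen in a six-membered non-aromatic ring, 0 hydrogen-bond donors instead of 1, and 9 heavy atoms instead of 6, so these compounds cannot show which difference matters. Nothing available accounts for the lower numbers.

The compounds shown leave open how much of the shift belongs to the piperidin-1-yl ring and how much to its methoxymethyl group, a question that an unsubstituted piperidin-1-yl would help to separate. Also open, as far as these compounds go, is whether the number stays low when the methoxymethyl group gives way to a longer chain such as ethoxymethyl, or to a carboxylic acid or an amine.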